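Removing the methoxy group from the benzylamide of compound 2

A few compounds are considered here, and "the series" means these few. Any claim that something is new, unique, unknown or untested is made for them only; others in the source may bear on it.

Of the compounds shown here, two from this series have been tested in an assay on microsomes from liver for inhibition of 3-hydroxy-3-methylglutaryl-coenzyme A reductase (Rattus norvegicus), read by scintillation counting, with stated times of 0.5 h and 0.75 h; a lower number here means a stronger inhibitor, a higher number a weaker inhibitor. Compound 1 `O=C(O)C[C@H](O)C[C@H](O)CCn1c(-c2ccc(F)cc2)nc(C(=O)NCc2ccccc2F)c1C1CC1` gives 1.5 nM in this assay. Compound 2 `COc1cccc(CNC(=O)c2nc(-c3ccc(F)cc3)n(CC[C@@H](O)C[C@@H](O)CC(=O)O)c2C2CC2)c1` gives 1.2 nM in this assay. These two differ only in the group on the saturated chain carbon bound to the amide-type nitrogen, a 3-methoxyphenyl in compound 2 in place of the 2-fluorophenyl of compound 1, and the step of a 1.3-fold lower number from compound 1 to compound 2 (0.10 log units; within the scatter) shows that the two numbers cannot be told apart. Compound 2 therefore stands at the same level as compound 1, not beyond it.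

Compound 3 `O=C(O)C[C@H](O)C[C@H](O)CCn1c(-c2ccc(F)cc2)nc(C(=O)NCc2ccccc2)c1C1CC1` is the next variation. Relative to compound 2 the change is hydrogen in place of methoxy on an aromatic carbon. Among the compounds with values here, the only step so far on this part of the molecule, from compound 1 to compound 2, swapped one substituted phenyl for another with no change beyond the scatter, and it says nothing direct about a bare phenyl. On that basis the expected step of a 1.3-fold higher number from compound 2 to compound 3 (0.12 log units; within the scatter) is small and of uncertain direction. Compound 3 is estimated at 1.6 nM in this assay, with a range from 0.6 nM to 4.5 nM.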

Compound 3, half-maximal inhibitory concentration: 1.4 nM
For compound 3 the middle estimate is 1.1-fold (0.06 log units) above the measured one, within the range that was stated.
By their numbers in this assay, from the lowest: compounds 2, 3 and 1 (each within the scatter of the next).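

With the plain benzyl amide of compound 3 alongside the two substituted forms, the ring can now be read with neither methoxy nor fluoro on it. In this assay, hydrogen in place of methoxy gives a 1.2-fold higher number from compound 2 to compound 3 (0.07 log units; within the scatter), and hydrogen in place of fluoro gives a 1.1-fold lower number from compound 1 to compound 3 (0.03 log units; within the scatter), so neither substituent can be told apart from hydrogen, and compound 1, compound 2 and compound 3 all stand at one level. No measurement is available that bears on why these numbers lie so close together.

The compounds leave open whether this level would hold for groups of another kind on the ring, such as an amine or a carboxylic acid, or for a longer chain between the amide nitrogen and the ring. They also leave open whether methoxy or fluoro would behave the same way elsewhere on the ring, since each appears here in one place only, and whether the shared core would show the same indifference with any other amide.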